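Adding a Nitro Group to Compound 1

A few compounds are considered here, and "the series" means these few. Any claim that something is new, unique, unknown or untested is made for them only; others in the source may bear on it.

In a functional assay on ECa-109 cells (Homo sapiens) for cytotoxicity, read by MTT assay, with a stated time of 48 h (on this read-out lower numbers stand for stronger inhibition and higher numbers for weaker inhibition), compound 1 `O=C1C(O)=C(C(c2ccccc2)c2c(-c3ccccc3)[nH]c3ccccc23)C(=O)c2ccccc21` gives 5180 nM, the lowest of the three measured numbers. Compound 2 `O=C1C(O)=C(C(c2cccs2)c2c[nH]c3ccccc23)C(=O)c2ccccc21` gives 12100 nM, and compound 3 `O=C1C(O)=C(C(c2ccc(Cl)cc2)c2c[nH]c3ccccc23)C(=O)c2ccccc21` gives 45800 nM. Within the data shown here, the only measured single step, a 3.8-fold higher number from compound 2 to compound 3 (0.58 log units; beyond the scatter), concerns a different position and a pair whose shared core is not that of compound 1, so it gives no direct guide here. Compound 4 `O=C1C(O)=C(C(c2ccc([N+](=O)[O-])cc2)c2c(-c3ccccc3)[nH]c3ccccc23)C(=O)c2ccccc21` differs from compound 1 by nitro in place of hydrogen on an aromatic carbon. Among the measured compounds shown here, no measured step touches this change, and the direction is open. Compound 4 is therefore expected to land close to compound 1, the expected step being a 1.4-fold higher number from compound 1 to compound 4 (0.13 log units; within the scatter). The estimate for compound 4 is 7000 nM, with a range from 2500 nM to 20000 nM.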

Compound 4, half-maximal inhibitory concentration: 5080 nM
Beside the measured number, compound 4's estimate is 1.4-fold (0.14 log units) above it; measured number inside the range.
By their numbers in this assay, from the lowest: compounds 4 and 1 (each within the scatter of the next); then compound 2; then compound 3.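

In this assay, nitro in place of hydrogen gives a 1.0-fold lower number from compound 1 to compound 4 (0.01 log units; within the scatter), so the phenyl to 4-nitrophenyl change leaves the number within the scatter. Among these compounds, this is the first measured view of this position on the core of compound 1, and it shows that the position accepts a group of 3 heavy atoms, para to a large group, with no change the assay can resolve. Nothing measured here bears on the reason for this result. From the compounds shown here alone, whether an amine or a carboxylic acid at this position would behave the same remains open.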